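This account rests on a few compounds, and the source may have more. Where it says the series, first, only, none or still open, it means among the compounds named here.

Compound 1 `C[C@@H]1CCCN1c1c(C#N)c2c(N)nc(Nc3cn[nH]c3)nc2n1C` and compound 2 `C[C@@H]1CCCN1c1c(C#N)c2c(N)nc(Nc3cnn(C)c3)nc2n1C` share one core; the difference between them is methyl in place of hydrogen on an aromatic nitrogen. In an assay on isolated protein for inhibition of Leucine-rich repeat serine/threonine-protein kinase 2 (Homo sapiens), read by TR-FRET and LanthaScreen, with stated times of 50 min and 30 min, in the presence of a further agent that is not named here (on this read-out lower numbers stand for stronger inhibition and higher numbers for weaker inhibition), compound 1 gives 6 nM and compound 2 gives 6 nM, so that no change at the digits printed from compound 1 to compound 2 (within the scatter). Compound 3 `Cc1n[nH]cc1Nc1nc(N)c2c(C#N)c(N3CCC[C@H]3C)n(C)c2n1` has a different core, which differs from the core of compound 1 by methyl in place of hydrogen on an aromatic carbon; in this assay compound 3 gives 42 nM, and a 7.0-fold higher number from compound 1 to compound 3 (0.85 log units; beyond the scatter). Compound 4 `Cc1nn(C)cc1Nc1nc(N)c2c(C#N)c(N3CCC[C@H]3C)n(C)c2n1` has not yet been measured and differs from compound 3 by methyl in place of hydrogen on an aromatic nitrogen. This is the same kind of change as that from compound 1 to compound 2, though here the place is also two ring bonds from the ring atom that bears a methyl group. For compound 4 the expected step in this assay is no change at the digits printed from compound 3 to compound 4 (within the scatter), because no change at the digits printed from compound 1 to compound 2 (within the scatter) held within the scatter. Compound 4 is therefore estimated at 42 nM, expected between 18 nM and 100 nM.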

Compound 4, half-maximal inhibitory concentration: 38 nM
Compound 4: the middle estimate sits 1.1-fold (0.04 log units) above what was measured, within the range that was stated.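

Methyl in place of hydrogen on the aromatic nitrogen carried over from one core to the other in this assay, with a 1.1-fold lower number from compound 3 to compound 4 (0.04 log units; within the scatter) matching the earlier step: the same change on two cores in this assay, no change at the digits printed (within the scatter) from compound 1 to compound 2 and a 1.1-fold lower number (0.04 log units; within the scatter) from compound 3 to compound 4, 1.1-fold (0.04 log units) apart, within the scatter of two such steps. Methyl in place of hydrogen on the aromatic carbon also kept its size when the nitrogen already carried methyl, with a 6.3-fold higher number from compound 2 to compound 4 (0.80 log units; beyond the scatter) matching its earlier step: the same change on two cores in this assay, a 7.0-fold higher number (0.85 log units; beyond the scatter) from compound 1 to compound 3 and a 6.3-fold higher number (0.80 log units; beyond the scatter) from compound 2 to compound 4, 1.1-fold (0.04 log units) apart, within the scatter of two such steps. Both methyl groups together give a 6.3-fold higher number from compound 1 to compound 4 (0.80 log units; beyond the scatter), yet two cores in one assay cannot show that either change would carry over in the same way to any other core.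

On these data alone, it remains open whether a larger group on that nitrogen, such as an ethyl group or a longer chain ending in an amine, would behave as methyl does. The same question applies to a group other than methyl on the aromatic carbon, such as chlorine or methoxy.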